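The source may hold more compounds than are shown below. What is called first, only, known or untested is meant among the compounds shown, and "the series" means these compounds.

In a functional assay on B16-F10 cells (Mus musculus) for antiproliferative activity, read by CCK-8 assay, with a stated time of 48 h (a lower number here means a stronger inhibitor, a higher number a weaker inhibitor), compound 1 (`COc1ccc(/C=C\c2cc(OC)c(OC)c(OC)c2)cc1OCc1ccc(C=O)cc1`), which carries a formyl group, gives 4200 nM as a measured number. Compound 2 (`COc1ccc(/C=C\c2cc(OC)c(OC)c(OC)c2)cc1OCc1ccc(CN2C[C@H](O)C[C@@H]2C(=O)O)cc1`) gives > 10000 nM as its reading, which is a limit of the assay. Compound 3 (`COc1ccc(/C=C\c2cc(OC)c(OC)c(OC)c2)cc1OCc1ccc(CN2CCCCC2C(=O)O)cc1`) gives > 10000 nM as its reading, again a limit and not a number. Compound 4 (`COc1ccc(/C=C\c2cc(OC)c(OC)c(OC)c2)cc1OCc1ccc(CNCCO)cc1`) carries (2-hydroxyethyl)amino in place of 2-carboxypiperidin-1-yl on a saturated chain carbon bound to an aromatic carbon. Going by the values given here, two measured steps bear on this change: an at least 2.3-fold higher number from compound 1 to compound 2 (0.37 log units; beyond the scatter) and an at least 2.3-fold higher number from compound 1 to compound 3 (0.37 log units; beyond the scatter) both brought in a carboxy group, which compound 4 lacks. A move toward a lower number is therefore expected, estimated as an at least 1.6-fold lower number from compound 3 to compound 4 (0.22 log units; that floor lies within the scatter) with its size uncertain. Compound 4 is expected at about 6000 nM (estimated range 1800 nM to 20000 nM).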

Compound 4, half-maximal inhibitory concentration: 6600 nM
Beside the measured number, compound 4's estimate is 1.1-fold (0.04 log units) below it; low and high end bracket the measured number.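

In this assay, (2-hydroxyethyl)amino on this saturated chain carbon gives compound 4 a measured number, where the two groups carrying a carboxy group gave only limits. The steps read an at least 1.5-fold lower number from compound 3 to compound 4 (0.18 log units; that floor lies within the scatter) and an at least 1.5-fold lower number from compound 2 to compound 4 (0.18 log units; that floor lies within the scatter) as floors within the scatter, and their true size stays unread because of a limit: the limit of > 10000 nM in this assay, at which 2 of the 4 values shown sit. The step of a 1.6-fold higher number from compound 1 to compound 4 (0.20 log units; within the scatter) stays within the scatter, so this amine leaves the reading where the formyl group had it.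

As far as these compounds go, compound 4 lacks both the ring and the carboxy group of compound 3, and which of the two matters stays open. Also open, from the compounds shown here alone, is how a plain piperidin-1-yl group or a longer chain on the nitrogen would read.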